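A few compounds are considered here, and "the series" means these few. Any claim that something is new, unique, unknown or untested is made for them only; others in the source may bear on it.

Of the compounds shown here, three of a shared core have been measured in a physicochemical assay for lipophilicity; a lower number here means a more polar compound, a higher number a more lipophilic compound. Compound 1 `Cc1csc2cc([C@H](C)Nc3ncnc(N)c3C#N)c(-c3ccccc3)c(=O)n12` gives 2.7 in this assay. Compound 2 `Cc1csc2cc([C@H](C)Nc3ncnc(N)c3C#N)c(-c3cccc(CN4CCC(N(C)CCC(F)(F)F)CC4)c3)c(=O)n12` gives 1.1 in this assay. Compound 3 `Cc1csc2cc([C@H](C)Nc3ncnc(N)c3C#N)c(Cc3cccc(CN(C)CC(C)C)c3)c(=O)n12` gives 2.3 in this assay, the second highest of the three numbers: it lies nearest to compound 1, whose value is higher by a margin beyond the scatter, and furthest from compound 2, whose value is lower by a margin well beyond the scatter.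

The step under consideration leads from compound 3 to compound 4 `Cc1csc2cc([C@H](C)Nc3ncnc(N)c3C#N)c(Cc3cccc(CN4CCC4)c3)c(=O)n12`, which has not yet been measured in this assay. The two differ in one place: azetidin-1-yl in place of isobutyl(methyl)amino on a saturated chain carbon bound to an aromatic carbon

Within the data shown here, no measured pair shows this same exchange, so nothing in the numbers at hand fixes its size. With the value of compound 3 at 2.3 as the starting point, the step from compound 3 to compound 4 is expected to be a modest downward one, a number 0.50 log units lower from compound 3 to compound 4 (beyond the scatter), somewhat beyond the scatter but far short of the gap separating compound 3 from compound 2. Compound 4 is therefore estimated at 1.8, with a likely range from 1.3 to 2.3.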

Compound 4, distribution coefficient: 0.5
Estimate against measurement, compound 4: 1.30 log units above; measured number below the stated range.
By their numbers in this assay, from the lowest: compound 4; then compound 2; then compound 3; then compound 1.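

In this assay, the exchange of isobutyl(methyl)amino for azetidin-1-yl on a saturated chain carbon bound to an aromatic carbon gives a large step, a number 1.80 log units lower from compound 3 to compound 4 (beyond the scatter). Among these compounds, it is the first single-place comparison in this set, and it shows that the number responds strongly to the amine at this place, even though both groups carry the same counts of hydrogen-bond donors and acceptors and no net charge. Nothing measured on these compounds accounts for the size of the step.

From the compounds shown here alone, it remains open whether the step follows the four-membered ring or the lower count of heavy atoms, a question that a pyrrolidin-1-yl or dimethylamino group at this place could help to separate. Going by these compounds, whether the same exchange would have a similar size elsewhere also remains open.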